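The source may hold more compounds than are shown below. What is called first, only, known or untested is meant among the compounds shown, and "the series" means these compounds.

Measured in a functional assay on A549 cells (Homo sapiens) for cytotoxicity, read by MTT assay, with a stated time of 24 h, tested at 20 uM; a higher number here means a weaker effect of the compound at the concentration tested, a lower number a stronger effect:
compound 1 `CCCOC(=O)CCC(=O)N1CCN(CCCOc2cc3c(Nc4ccc(F)c(Cl)c4)ncnc3cc2OC)CC1` gives 87%
compound 2 `CCCCCOC(=O)CCC(=O)N1CCN(CCCOc2cc3c(Nc4ccc(F)c(Cl)c4)ncnc3cc2OC)CC1` gives 81.2%
compound 3 `CCCCCCCCCOC(=O)CCC(=O)N1CCN(CCCOc2cc3c(Nc4ccc(F)c(Cl)c4)ncnc3cc2OC)CC1` gives 79.7%

Compound 3 stands lowest of the three in this assay, yet compound 2 lies within the scatter of it, as does compound 1. The next compound, compound 4 `CCCCCCCCCCCCCCOC(=O)CCC(=O)N1CCN(CCCOc2cc3c(Nc4ccc(F)c(Cl)c4)ncnc3cc2OC)CC1`, differs from compound 3 only by pentyl in place of hydrogen on a saturated chain carbon, nine bonds along the chain from an oxygen next to a carbonyl group. For the measured compounds named here, the steps that bear on this change are the chain extensions already seen: a number 5.8 percentage points lower from compound 1 to compound 2 (within the scatter), a number 7.3 percentage points lower from compound 1 to compound 3 (within the scatter) and a number 1.5 percentage points lower from compound 2 to compound 3 (within the scatter), all within the scatter. From these, no step beyond the scatter is expected in this assay for compound 4, at most a slight further drift downward, a number 2.7 percentage points lower from compound 3 to compound 4 (within the scatter). Compound 4 is therefore estimated at 77%, in the range 66% to 88%.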

Compound 4, a percentage reported as activity, at one concentration (the size of the read-out at that concentration, not a potency): 92.3%
For compound 4 the middle estimate is 15.3 percentage points below the measured one; measured number above the stated range.
By their numbers in this assay, from the lowest: compounds 3, 2, 1 and 4 (each within the scatter of the next, the first and the last beyond it).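

In this assay, for the compounds shown here, the ester chain first makes a difference at its long end: pentyl in place of hydrogen, on a saturated chain carbon nine bonds along the chain from an oxygen next to a carbonyl group, brings a number 12.6 percentage points higher from compound 3 to compound 4 (beyond the scatter) and the longer change brings a number 11.1 percentage points higher from compound 2 to compound 4 (beyond the scatter) as the only steps beyond the scatter. Against any steady trend with chain length stands a number 5.3 percentage points higher from compound 1 to compound 4 (within the scatter) so the longest chain cannot be told apart from the shortest. No measurement available here offers an explanation for this result. On these data alone, whether a longer chain would continue upward remains open. So does whether a carboxylic acid or an amide in place of the ester would give the same reading.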